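Trading a chlorophenyl ring for a small carbonyl group

A few compounds are considered here, and "the series" means these few. Any claim that something is new, unique, unknown or untested is made for them only; others in the source may bear on it.

Three compounds built on one shared core have been run in an ADME assay on HEp-2 cells (Homo sapiens) for cytotoxicity, read by CCK-8 assay, with a stated time of 6 days; on this read-out higher numbers stand for lower toxicity in this test and lower numbers for higher toxicity in this test. Compound 1 `NCCNc1cc(N2CCN(C(=O)CCc3ccccc3)CC2)nc2ccccc12` carries a phenethylcarbonyl group on an amine nitrogen in a ring. In this assay compound 1 reaches only the limit of the test, > 100000 nM, so no number is known for it. Compound 2 `NCCNc1cc(N2CCN(c3cccc(Cl)c3)CC2)nc2ccccc12` carries a 3-chlorophenyl group in that place and gives 6400 nM. Compound 3 `NCCNc1cc(N2CCN(c3ccccc3Cl)CC2)nc2ccccc12` carries a 2-chlorophenyl group there and gives 20800 nM, the higher of the two numbers on hand, with the step of a 3.3-fold higher number from compound 2 to compound 3 (0.51 log units; beyond the scatter) setting the gap to its nearest neighbour.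

Compound 4 `CC(C)C(=O)N1CCN(c2cc(NCCN)c3ccccc3n2)CC1` differs from compound 3 in one place: isopropylcarbonyl in place of 2-chlorophenyl on an amine nitrogen in a ring. Within the data shown here, two measured steps bear on this exchange of an aromatic ring for a carbonyl group. Going the other way, from carbonyl to aryl, the number fell: an at least 4.8-fold lower number from compound 1 to compound 3 (0.68 log units; beyond the scatter) and an at least 15-fold lower number from compound 1 to compound 2 (1.19 log units; beyond the scatter). Going by these compounds, both start from a value that is only a limit (the limit of > 100000 nM in this assay, at which 1 of the 3 values shown sits), so the true size of the fall is unknown, yet its direction is clear. Putting a carbonyl group back in place of the 2-chlorophenyl group is therefore expected to raise the number, though the entering group is isopropylcarbonyl rather than phenethylcarbonyl, so compound 1 is only a rough guide. Compound 4 is thus estimated at 70000 nM, within 25000 nM to 200000 nM, an expected step of a 3.4-fold higher number from compound 3 to compound 4 (0.53 log units; beyond the scatter), with a fair chance that only the limit is reported again.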

Compound 4, half-maximal cytotoxic concentration: > 100000 nM
Compound 4 ended at the assay's limit; the forecaster's own chance of this, stated with the estimate: 40%; middle value at least 1.4-fold (0.15 log units) from the limit.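

In this assay, the change to isopropylcarbonyl brings an at least 4.8-fold higher number from compound 3 to compound 4 (0.68 log units; beyond the scatter), and the same change from the other chlorophenyl compound brings an at least 15-fold higher number from compound 2 to compound 4 (1.19 log units; beyond the scatter). Until now, only compound 1 showed that a carbonyl group on this ring nitrogen could carry the number out of the measurable range, and that group has a phenyl ring at the end of its chain. Compound 4 shows that a smaller group with no ring does the same, so among these four compounds both carbonyl compounds end higher than both chlorophenyl compounds, with none going against this, and the step between compound 1 and compound 4 cannot be read because each stops at a limit: the limit of > 100000 nM in this assay, at which 2 of the 4 values shown sit.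

Going by these compounds, whether isopropylcarbonyl and phenethylcarbonyl differ at all in this test therefore stays open. Also open, on these data alone, is whether the carbonyl itself matters or merely the loss of the chlorophenyl ring, a question that a plain isopropyl or benzyl group on the same nitrogen, or an unsubstituted phenyl ring, would help to settle.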